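Acrylonitrile series: pyrrolyl to chlorophenyl, compound 2 to compound 4

The compounds below may be only part of what the source reports. "The series", "measured", "known", "first", "only" and "open" are said of these compounds alone.

In a functional assay on SJ-G2 cells (Homo sapiens) for inhibition, read by MTT assay, with a stated time of 72 h (a lower number here means a stronger inhibitor of growth, a higher number a weaker inhibitor of growth), compound 1 `N#C/C(=C\c1c(F)c(F)c(F)c(F)c1F)C(=O)c1c[nH]c2ccccc12` gives 14000 nM. Compound 2 `COc1ccc(CNC(=O)/C(C#N)=C/c2ccc[nH]2)cc1` reaches only the limit of this assay, > 50000 nM. Compound 3 `N#C/C(=C\c1ccco1)C(=O)NCc1ccc(Cl)c(Cl)c1` likewise stops at the limit, > 50000 nM. Compound 2 thus stands at the limit of > 50000 nM in this assay, at which 2 of the 3 values shown sit; of the three values shown, only compound 1 gives a number. Compound 4 `COc1ccc(CNC(=O)/C(C#N)=C/c2ccc(Cl)cc2)cc1` is not yet measured and differs from compound 2 by 4-chlorophenyl in place of 1H-pyrrol-2-yl on a double-bonded chain carbon bound to a double-bonded chain carbon. Within the data shown here, no measured step of this kind exists among the compounds, so neither size nor direction can be read from the data. Starting from a limit, the step is expected to be small, an at least 1.2-fold lower number from compound 2 to compound 4 (0.09 log units; that floor lies within the scatter), likely within scatter. The estimate for compound 4 in this assay is 40000 nM, with a range from 15000 nM to 100000 nM.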

Compound 4, concentration for 50% growth inhibition: 11000 nM
Compound 4: middle estimate off by 3.6-fold (0.56 log units), on the high side; the measured number lies below the stated range.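

Among these compounds, on the double-bonded chain carbon bound to a double-bonded chain carbon, 4-chlorophenyl in place of 1H-pyrrol-2-yl gives the first readable step in this assay: an at least 4.5-fold lower number from compound 2 to compound 4 (0.65 log units; beyond the scatter). Among the compounds shown here, the group at this position therefore matters for growth inhibition, which no earlier pair could show. The true size of the step stays unknown because compound 2 stands at a limit: the limit of > 50000 nM in this assay, at which 2 of the 4 values shown sit.

The compounds shown do not separate the chlorine from the change of ring or the loss of the hydrogen-bond donor. From the compounds shown here alone, whether a carboxylic acid or a dimethylamino group in place of the chlorine would keep the step also stays open.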